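From Isopropyl to Phenethyl at the Assay Limit

The source may report more compounds than this note shows. Statements on the series, on what has been measured and on what is new or still open speak of the compounds shown alone.

Compound 1 `CCCCOC(=O)CNC(=O)[C@H](CSc1ccc([N+](=O)[O-])cc1[N+](=O)[O-])NC(=O)CC[C@H](NC(=O)OC)C(=O)OCCCC` and compound 2 `CCCCOC(=O)CNC(=O)[C@H](CSc1ccc([N+](=O)[O-])cc1[N+](=O)[O-])NC(=O)CC[C@H](NC(=O)C(C)C)C(=O)OCCCC` share one core and were both measured in a toxicity assay on KB cells (Homo sapiens) for cytotoxicity, read by fluorescence, with a stated time of 3 days; on this read-out lower numbers stand for an effect already at smaller amounts and higher numbers for an effect only at larger amounts of compound. Compound 1 gives > 300 uM, which is a limit of the assay and not a number. Compound 2 gives > 300 uM, which is also a limit. Compound 2 therefore stands at the limit of > 300 uM in this assay, at which 2 of the 2 values shown sit. Among the measured compounds shown here, the only measured step, a step that the two limits leave unreadable from compound 1 to compound 2, also swaps the group on a carbonyl carbon, but it offers no size to carry forward.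

Compound 3 `CCCCOC(=O)CNC(=O)[C@H](CSc1ccc([N+](=O)[O-])cc1[N+](=O)[O-])NC(=O)CC[C@H](NC(=O)CCc1ccccc1)C(=O)OCCCC` has phenethyl in place of isopropyl on a carbonyl carbon. For the measured compounds named here, with that one unreadable step as the sole guide, no clear change is expected in this assay. The estimated step is a number no higher from compound 2 to compound 3 (the limit leaves the size open). Compound 3 is expected at 300 uM, with an estimated range from 100 uM to 400 uM, and will quite likely return only a limit.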

Compound 3, concentration for half-maximal effect: > 300 uM
Compound 3: only a limit was reported; the forecaster's own chance of this, stated with the estimate: 80%; the middle value lies on the limit itself.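

No step can be read among compound 1, compound 2 and compound 3 in this assay, and all three stand at one limit rather than at a number: the limit of > 300 uM in this assay, at which 3 of the 3 values shown sit. The compounds shown leave open at what concentration, if any, each of the three would show an effect.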